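The compounds below may be only part of what the source reports. "The series", "measured", "known", "first", "only" and "open" are said of these compounds alone.

For the measured compounds named here, the two compounds measured so far share one core and differ only in the aryl group on a saturated ring carbon. Compound 1 `CC1=C(C(=O)Nc2ccccc2Cl)C(c2cccc(Br)c2)NC(=O)N1` carries a 3-bromophenyl there. In an ADME assay on Vero cells (Chlorocebus sabaeus) for cytotoxicity, read by XTT assay, with a stated time of 72 h (on this read-out higher numbers stand for lower toxicity in this test and lower numbers for higher toxicity in this test), compound 1 gives > 100000 nM, which is a limit of the test and not a number. Compound 2 `CC1=C(C(=O)Nc2ccccc2Cl)C(c2ccc(C)cc2)NC(=O)N1` carries a 4-methylphenyl instead. In this assay compound 2 gives > 100000 nM, again a limit rather than a number. The step that the two limits leave unreadable from compound 1 to compound 2 cannot be read because of the limit of > 100000 nM in this assay, at which 2 of the 2 values shown sit. Compound 3 `COc1cccc(C2NC(=O)NC(C)=C2C(=O)Nc2ccccc2Cl)c1` has not yet been measured; it differs from compound 2 by 3-methoxyphenyl in place of 4-methylphenyl on a saturated ring carbon. Going by the values given here, the only measured step bearing on this change is unreadable, so no size or direction can be taken from it. Compound 3 is expected to give 150000 nM in this assay, with a range from 50000 nM to 400000 nM, and most likely again only a limit. The estimated step that the limit leaves unreadable from compound 2 to compound 3 is therefore expected to stay within the scatter.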

Compound 3, half-maximal cytotoxic concentration: > 100000 nM
Compound 3: only a limit was reported; the forecaster's own chance of this, stated with the estimate: 85%; the middle value is on the limit's open side.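

Compound 3 also stops at a limit of the test, so no step among compound 1, compound 2 and compound 3 can be read: the limit of > 100000 nM in this assay, at which 3 of the 3 values shown sit.

What the compounds shown leave open is how far the aryl group changes toxicity in this assay, since none gives an actual number.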